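Adding a Methoxy Group to a Chalcone-Like Pyrazole

The source may report more compounds than this note shows. Statements on the series, on what has been measured and on what is new or still open speak of the compounds shown alone.

Compound 1, `COc1cc(-c2cc(/C=C/C(=O)c3ccc(N)cc3)[nH]n2)cc(OC)c1OC`: in a functional assay on T47D cells (Homo sapiens) for inhibition, read by sulforhodamine B assay, with a stated time of 48 h (a higher number here means that more compound is tolerated, a lower number that less compound is tolerated), compound 1 gives > 100000 nM, which is a limit of the assay rather than a number.
Compound 2, `COc1ccc(C(=O)/C=C/c2cc(-c3cc(OC)c(OC)c(OC)c3)n[nH]2)cc1OC`: in this assay compound 2 gives > 100000 nM, again only a limit.

Compound 2 therefore stands at the top end of what this assay can report, and the same is true of everything measured so far: the limit of > 100000 nM in this assay, at which 2 of the 2 values shown sit. Among the compounds with values here, the only measured step, a step that the two limits leave unreadable from compound 1 to compound 2, has a limit at both ends and so its size cannot be read. Compound 3, `COc1cc(C(=O)/C=C/c2cc(-c3cc(OC)c(OC)c(OC)c3)n[nH]2)cc(OC)c1OC`, differs from compound 2 by methoxy in place of hydrogen on an aromatic carbon. Within the data shown here, no measured step bears on this change, so there is nothing to argue for a shift beyond the scatter in either direction. Compound 3 is thus expected at the same ceiling, estimated as 150000 nM, with a range from 30000 nM to 600000 nM. The step that the limit leaves unreadable from compound 2 to compound 3 is expected to be essentially none, with a further limit the most likely report.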

Compound 3, concentration lethal to 50% of the cells: 5860 nM
For compound 3 the middle estimate is 26-fold (1.41 log units) above the measured one; measured number outside the range, below it.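

The methoxy that replaces hydrogen on this aromatic carbon, ortho to a methoxy group and meta to a large group, gives the first step whose direction can be read in this assay: an at least 17-fold lower number from compound 2 to compound 3 (1.23 log units; beyond the scatter). A lower number here means that less compound is tolerated, so one small addition to this ring moves the series off the ceiling and into the range the assay can report. Compound 3 is the only one of the three with a true number, and the others remain at the ceiling: the limit of > 100000 nM in this assay, at which 2 of the 3 values shown sit.

The limit for compound 2 hides the full size of this step, and the step from compound 1 to compound 2 cannot be read at all. The compounds shown also leave open whether a hydroxyl group or an ethoxy group on this same carbon would lower the number too, or whether methoxy itself is required.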